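Cyclopropyl for isopropyl on a sulfonyl: expected exposure

This account rests on a few compounds, and the source may have more. Where it says the series, first, only, none or still open, it means among the compounds named here.

Four compounds share one core and were compared in an ADME assay on the whole organism (plasma) for pharmacokinetics, with Rattus norvegicus as the target, with a stated time of 24 h, at a dose of 10 mg/kg by the oral route; a lower number here means less compound in the circulation, a higher number more compound in the circulation at the dose given. Compound 1 `Cc1ccc2c(c1)c(-c1ccc[nH]c1=O)c(C(=O)NS(=O)(=O)C(C)C)n2Cc1cc(F)ccc1F` gives 3400 ng.h/mL, and compound 2 `Cc1ccc2c(c1)c(-c1ccc[nH]c1=O)c(C(=O)NS(=O)(=O)C1CC1)n2Cc1cc(F)ccc1F` gives 4530 ng.h/mL. The change between them is cyclopropyl in place of isopropyl on a sulfonyl sulfur, and the step was a 1.3-fold higher number from compound 1 to compound 2 (0.12 log units; within the scatter). Compound 3 `CCc1ccc2c(c1)c(-c1ccc[nH]c1=O)c(C(=O)NS(=O)(=O)C(C)C)n2Cc1cc(F)ccc1F` gives 411 ng.h/mL and differs from compound 1 by methyl in place of hydrogen on a saturated chain carbon bound to an aromatic carbon; here the step was an 8.3-fold lower number from compound 1 to compound 3 (0.92 log units; beyond the scatter), leaving compound 3 with the lowest number of the three.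

Compound 4 `CCc1ccc2c(c1)c(-c1ccc[nH]c1=O)c(C(=O)NS(=O)(=O)C1CC1)n2Cc1cc(F)ccc1F` has not been measured yet. It differs from compound 3 by cyclopropyl in place of isopropyl on a sulfonyl sulfur, the same change already seen from compound 1 to compound 2, at the same place. Because that earlier step was a 1.3-fold higher number from compound 1 to compound 2 (0.12 log units; within the scatter), the expected step for compound 4 is a 1.3-fold higher number from compound 3 to compound 4 (0.11 log units; within the scatter). This expectation rests on one pair only, so its range is kept wide. Compound 4 is estimated to give 530 ng.h/mL in this assay, with the likely spread running from 200 ng.h/mL to 1400 ng.h/mL.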

Compound 4, area under the concentration-time curve: 6140 ng.h/mL
Estimate against measurement, compound 4: 12-fold (1.06 log units) below; the measured number lies above the stated range.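

In this assay, the swap of isopropyl for cyclopropyl on the sulfonyl sulfur gave a 15-fold higher number from compound 3 to compound 4 (1.17 log units; beyond the scatter), so the size of this step did not carry from one core to the other: the same change on two cores in this assay, a 1.3-fold higher number (0.12 log units; within the scatter) from compound 1 to compound 2 and a 15-fold higher number (1.17 log units; beyond the scatter) from compound 3 to compound 4, 11-fold (1.05 log units) apart, beyond the scatter of two such steps

The added methyl shows the same dependence, giving a 1.4-fold higher number from compound 2 to compound 4 (0.13 log units; within the scatter) when cyclopropyl sits on the sulfonyl sulfur, so its effect in this assay changes with the group present there: the same change on two cores in this assay, an 8.3-fold lower number (0.92 log units; beyond the scatter) from compound 1 to compound 3 and a 1.4-fold higher number (0.13 log units; within the scatter) from compound 2 to compound 4, 11-fold (1.05 log units) apart, beyond the scatter of two such steps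

This shows that the two changes cannot be treated as separate, additive steps among these four compounds, with compound 3 falling far below both compound 1 and compound 4, but it does not show why this happens or whether the same would hold on any other core.

On these data alone, it remains open whether a longer chain such as n-butyl, or a phenyl ring, on the sulfonyl sulfur would give numbers like compound 4 or like compound 3. As far as these compounds go, it also remains open whether a further methyl added to the saturated chain would produce a similar dependence on the sulfonyl group.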